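This account rests on a few compounds, and the source may have more. Where it says the series, first, only, none or still open, it means among the compounds named here.

Measured in an assay for binding affinity to Adrenergic receptor alpha-1 (Rattus norvegicus); on this read-out lower numbers stand for stronger inhibition and higher numbers for weaker inhibition:
compound 1 `COc1cc2nc(N3CCN(/C(S)=N/c4ccccc4)CC3)nc(N)c2cc1OC` — 0.00692 nM
compound 2 `COc1cc2nc(N3CCN(/C(S)=N/C4CCCCC4)CC3)nc(N)c2cc1OC` — 5.37 nM
compound 3 `COc1cc2nc(N3CCN(/C(S)=N/c4ccc(N=[N+]=[N-])cc4)CC3)nc(N)c2cc1OC` — 20 nM

Compound 3 gives the highest number of the three; the nearest is compound 2, with a 3.7-fold higher number from compound 2 to compound 3 (0.57 log units; beyond the scatter) between them, and the furthest is compound 1, with a 2900-fold higher number from compound 1 to compound 3 (3.46 log units; beyond the scatter).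

Compound 4 `COc1cc2nc(N3CCN(/C(S)=N/c4ccc(NC(=S)N5CC5)cc4)CC3)nc(N)c2cc1OC` carries a group of 6 heavy atoms (3 carbon, 2 nitrogen, 1 sulfur; one three-membered non-aromatic ring with 1 hetero atom) in place of a group of 3 heavy atoms (3 nitrogen; no ring), on an aromatic carbon. For the measured compounds named here, no measured step swaps one substituent at that aromatic carbon for another. The step from compound 1 to compound 3, a 2900-fold higher number from compound 1 to compound 3 (3.46 log units; beyond the scatter), shows that placing a group there costs much; compound 4 keeps a group there, so a step of that size in this assay is not expected. A modest shift, probably toward a somewhat higher number, is estimated: a 1.5-fold higher number from compound 3 to compound 4 (0.18 log units; within the scatter), giving compound 4 an expected 30 nM within 6 nM to 150 nM.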

Compound 4, half-maximal inhibitory concentration: 97.7 nM
Compound 4: the middle estimate sits 3.3-fold (0.51 log units) below what was measured; the measured number falls inside the stated range.
By their numbers in this assay, from the lowest: compound 1; then compound 2; then compound 3; then compound 4.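

In this assay, the aromatic carbon para to a large group remains sensitive once it is substituted: a 4.9-fold higher number from compound 3 to compound 4 (0.69 log units; beyond the scatter), so the cost does not stop at azido. Relative to hydrogen at that carbon, the larger group gives a 14000-fold higher number from compound 1 to compound 4 (4.15 log units; beyond the scatter), and the whole substituted phenyl gives an 18-fold higher number from compound 2 to compound 4 (1.26 log units; beyond the scatter), a wider gap to cyclohexyl than azido alone left. No supporting data on the origin of this shift are available. On these data alone, whether the rise follows group size or the three-membered ring itself stays open; a simple amine or methoxy at that carbon would bear on this.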